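The compounds below may be only part of what the source reports. "The series", "measured", "known", "first", "only" and "open" are said of these compounds alone.

Measured so far in a functional assay on PC-12 cells (Rattus norvegicus) for cytotoxicity, read by MTT assay, with stated times of 2 h and 24 h, tested at 10 uM; on this read-out higher numbers stand for a stronger effect at the one concentration tested and lower numbers for a weaker effect:
compound 1 `Oc1cc(C(F)(F)F)ccc1-c1nc(-c2ccccc2O)n(-c2ccc(C(F)(F)F)cc2)n1` — 102%
compound 2 `Oc1cc(C(F)(F)F)ccc1-c1nc(-c2ccccc2O)n(-c2ccc(OC(F)(F)F)cc2)n1` — 92.5%

Among the measured compounds shown here, compound 2 stands at the lower of the two numbers in this assay, with compound 1 as its only neighbour; the step of a number 9.5 percentage points lower from compound 1 to compound 2 (within the scatter) is within the scatter, so the two cannot be ordered.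

Compound 3 `N#Cc1ccc(-n2nc(-c3ccc(C(F)(F)F)cc3O)nc2-c2ccccc2O)cc1` is not yet measured. It differs from compound 2 in one place: cyano in place of trifluoromethoxy on an aromatic carbon.

For the measured compounds named here, the one measured step at that position, a number 9.5 percentage points lower from compound 1 to compound 2 (within the scatter), changed one group for another without moving the read-out beyond the scatter. Going by the values given here, no step with cyano at this position exists, so the expectation rests on that single comparison. A step of a number 2.5 percentage points lower from compound 2 to compound 3 (within the scatter) is expected, that is, none beyond the scatter in either direction. Compound 3 is therefore estimated at 90%, with a range from 70% to 105%.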

Compound 3, a percentage reported as activity, at one concentration (the size of the read-out at that concentration, not a potency): 98.9%
Beside the measured number, compound 3's estimate is 8.9 percentage points below it; measured number inside the range.
By their numbers in this assay, from the lowest: compounds 2, 3 and 1 (each within the scatter of the next).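

Cyano, with 2 heavy atoms and a triple bond, takes the place of trifluoromethoxy, with 5 heavy atoms, on this aromatic carbon para to a large group, and this assay still does not separate the compounds: the step is a number 6.4 percentage points higher from compound 2 to compound 3 (within the scatter) and, against trifluoromethyl, a number 3.1 percentage points lower from compound 1 to compound 3 (within the scatter). Among the compounds shown here, the single earlier step covered only two fluorinated groups, whereas the series now shows three groups at this position that cannot be ordered, one of them without fluorine. No measurement available offers an explanation for this flat result.

On these data alone, whether any group at this position moves the read-out beyond the scatter remains open. An amine or a carboxylic acid on this aromatic carbon would test that, and the effect of changes elsewhere on the shared core is equally unresolved.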